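A few compounds are considered here, and "the series" means these few. Any claim that something is new, unique, unknown or untested is made for them only; others in the source may bear on it.

Measured in an assay on CHO cells for displacement of a labelled ligand from transient receptor potential cation channel subfamily V member 1 (Rattus norvegicus), read by scintillation counting, with a stated time of 60 min; a higher number here means a weaker inhibitor, a lower number a stronger inhibitor:
compound 1 `CC(C(=O)NCc1ccc(C(C)(C)C)cc1)c1ccc(NS(C)(=O)=O)c(Cl)c1` gives 30.7 nM
compound 2 `CC(C(=O)NCc1ccc(C(C)(C)C)cc1)c1ccc(NS(C)(=O)=O)c(Br)c1` gives 7.4 nM
compound 3 `CC(C(=O)NCc1ccc(C(C)(C)C)cc1)c1ccc(NS(C)(=O)=O)c(I)c1` gives 23.3 nM

Compound 3 holds the second highest of the three numbers in this assay: the step of a 1.3-fold lower number from compound 1 to compound 3 (0.12 log units; within the scatter) stays within the scatter, whereas the step of a 3.1-fold higher number from compound 2 to compound 3 (0.50 log units; beyond the scatter) lies beyond it. Compound 4 `CC(C(=O)NCc1ccc(C(C)(C)C)cc1)c1ccc(NS(C)(=O)=O)c(C#N)c1` differs from compound 3 in one place: cyano in place of iodo on an aromatic carbon. Within the data shown here, no measured step exchanges a halogen for a cyano group, so none bears directly on this change; the halogen exchanges a 4.1-fold lower number from compound 1 to compound 2 (0.62 log units; beyond the scatter) and a 3.1-fold higher number from compound 2 to compound 3 (0.50 log units; beyond the scatter) were modest, and the three numbers span a narrow range. Compound 4 is therefore expected to land near compound 3, with no step beyond the scatter claimed but wide uncertainty. For compound 4 the estimate in this assay is 40 nM, range 8 nM to 200 nM, which is an expected step of a 1.7-fold higher number from compound 3 to compound 4 (0.23 log units; within the scatter).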

Compound 4, inhibition constant: 344 nM
The estimate for compound 4 lay 8.6-fold (0.93 log units) below the measured number; the measured number lies above the stated range.
By their numbers in this assay, from the lowest: compound 2; then compounds 3 and 1 (each within the scatter of the next); then compound 4.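

At this position, ortho to a methanesulfonamido group, the three halogens differ only modestly, whereas cyano brings a large change in this assay: a 15-fold higher number from compound 3 to compound 4 (1.17 log units; beyond the scatter), an 11-fold higher number from compound 1 to compound 4 (1.05 log units; beyond the scatter) and a 46-fold higher number from compound 2 to compound 4 (1.67 log units; beyond the scatter). The position therefore does not tolerate every small group equally, and the exchange of a halogen for cyano weakens inhibition well beyond the differences among the halogens. The data shown offer no measurement that explains this gap.

Still open, as far as these compounds go, is how a methyl group, a methoxy group or an amine would compare at this position, and whether any of them would match the halogens or fall with cyano.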